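The compounds below may be only part of what the source reports. "The series", "measured", "known", "first", "only" and "open" are said of these compounds alone.

Measured so far in a functional assay on a cell-free system (plasma, Oryctolagus cuniculus) for inhibition, with stated times of 5 min, 1 min and 6 min; a lower number here means a stronger inhibitor, a higher number a weaker inhibitor:
compound 1 `C=CCOn1c(-c2cccc(C#N)c2)nc(C)c1C(=O)OCC`, 5860 nM
compound 2 `CCOC(=O)c1c(C)nc(-c2cccc(C#N)c2)n1OCc1ccccc1`, 5930 nM
compound 3 `CCOC(=O)c1c(C)nc(-c2cccc(C#N)c2)n1OCc1ccc(Cl)cc1`, 6830 nM

Compound 1 shows the lowest of the three numbers, yet its gaps to the others are small: a 1.0-fold higher number from compound 1 to compound 2 (0.01 log units; within the scatter) and a 1.2-fold higher number from compound 1 to compound 3 (0.07 log units; within the scatter) both lie within the scatter. Compound 4 `CCOC(=O)c1c(C)nc(-c2cccc(C#N)c2)n1OCc1ccc(C(=O)OC)cc1` is not yet measured and differs from compound 1 as follows: 4-(methoxycarbonyl)phenyl in place of vinyl on a saturated chain carbon bound to an oxygen on an aromatic ring. For the measured compounds named here, three measured steps bear on this change. Replacing vinyl by phenyl (a 1.0-fold higher number from compound 1 to compound 2 (0.01 log units; within the scatter)) or by 4-chlorophenyl (a 1.2-fold higher number from compound 1 to compound 3 (0.07 log units; within the scatter)) left the number essentially unchanged, and putting chloro in place of hydrogen on the aromatic ring (a 1.2-fold higher number from compound 2 to compound 3 (0.06 log units; within the scatter)) did the same. A 4-(methoxycarbonyl)phenyl group is therefore expected to behave alike, giving no step beyond the scatter in this assay. For compound 4 the expected step is a 1.1-fold higher number from compound 1 to compound 4 (0.05 log units; within the scatter). Compound 4 is thus estimated at 6500 nM, with a range from 3300 nM to 13000 nM.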

Compound 4, half-maximal inhibitory concentration: 9470 nM
For compound 4 the middle estimate is 1.5-fold (0.16 log units) below the measured one; the measured number falls inside the stated range.
By their numbers in this assay, from the lowest: compounds 1, 2, 3 and 4 (each within the scatter of the next).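

In this assay, the larger 4-(methoxycarbonyl)phenyl group also fits this place without a step beyond the scatter, with a 1.6-fold higher number from compound 1 to compound 4 (0.21 log units; within the scatter) as the step from the vinyl compound. On the aromatic carbon, methoxycarbonyl likewise stays within the scatter whether it replaces hydrogen, with a 1.6-fold higher number from compound 2 to compound 4 (0.20 log units; within the scatter) as the step, or chloro, with a 1.4-fold higher number from compound 3 to compound 4 (0.14 log units; within the scatter) as the step. No measurement at hand offers an explanation for these small steps. As far as these compounds go, whether an amine or a carboxylic acid on that aromatic carbon, or a longer chain at this place, would give a step beyond the scatter remains open.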